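A few compounds are considered here, and "the series" means these few. Any claim that something is new, unique, unknown or untested is made for them only; others in the source may bear on it.

Compound 1 `CSc1nc(SC)c2ncn([C@@H]3C[C@@H](O)[C@H](CO)O3)c2n1` reaches only the limit of > 300 uM in a functional assay on HL-60 cells (Homo sapiens); a lower number here means a stronger inhibitor, a higher number a weaker inhibitor. Compound 2 `Nc1nc(Br)nc2c1ncn2[C@@H]1C[C@@H](O)[C@H](CO)O1` gives 41 uM in this assay, the only plain number shown. The other value shown, that of compound 1, is a limit (the limit of > 300 uM in this assay, at which 1 of the 2 values shown sits). Compound 3 `CSc1nc(N)c2ncn([C@@H]3C[C@@H](O)[C@H](CO)O3)c2n1` carries methylsulfanyl in place of bromo on an aromatic carbon. No step between measured compounds is shown, so the step from compound 2 to compound 3 is expected to be a loss of potency of moderate size, a 2.9-fold higher number from compound 2 to compound 3 (0.47 log units; beyond the scatter), beyond the usual scatter. Compound 3 is therefore estimated at 120 uM, within a range from 40 uM to 300 uM.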

Compound 3, concentration for 50% inhibition: > 300 uM
Compound 3 was reported as a limit (the forecaster's own chance of this, stated with the estimate: 30%); middle value at least 2.5-fold (0.39 log units) away from the limit.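

With the amino group kept, methylsulfanyl in place of bromo on the aromatic carbon between two ring nitrogen atoms gives an at least 7.3-fold higher number from compound 2 to compound 3 (0.86 log units; beyond the scatter) in this assay, so this position is sensitive to the change. Going by these compounds, compound 3 gives > 300 uM, which is a limit, so the full size of the step stays unknown. The step from compound 1 to compound 3 cannot be read, as both values are limits: the limit of > 300 uM in this assay, at which 2 of the 3 values shown sit.

On these data alone, it remains open whether chloro or a dimethylamino group on this carbon would keep the potency of compound 2.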